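This account rests on a few compounds, and the source may have more. Where it says the series, first, only, none or still open, it means among the compounds named here.

Measured in a functional assay on MCF7 cells (Homo sapiens) for cytotoxicity, read by sulforhodamine B assay, with a stated time of 48 h; a lower number here means a stronger inhibitor, a higher number a weaker inhibitor:
- compound 1 `COc1cccc(/C=C/C(=O)c2cccc(-c3cccc(F)c3)c2)c1OC`: 11700 nM
- compound 2 `COc1ccccc1/C=C/C(=O)c1cccc(-c2cccc(F)c2)c1`: 18900 nM
- compound 3 `COc1ccc(/C=C/C(=O)c2cccc(-c3cccc(F)c3)c2)cc1OC`: 4620 nM

Compound 2 is not separated from compound 1, as a 1.6-fold higher number from compound 1 to compound 2 (0.21 log units; within the scatter) shows, while compound 3 gives a lower number, beyond the scatter. Next comes compound 4 `O=C(/C=C/c1ccc(Cl)cc1)c1cccc(-c2cccc(F)c2)c1`, with 4-chlorophenyl in place of 2-methoxyphenyl on a double-bonded chain carbon bound to a double-bonded chain carbon. Within the data shown here, the one measured step, a 1.6-fold higher number from compound 1 to compound 2 (0.21 log units; within the scatter), removes a methoxy group and bears only loosely on this change, and no measured compound carries chlorine. With compound 3 at 4620 nM as the lowest reference, a modest move to a lower number in this assay is expected. The estimate amounts to a 2.1-fold lower number from compound 2 to compound 4 (0.32 log units; beyond the scatter). For compound 4 the estimated value is 9000 nM, with an expected range of 3000 nM to 25000 nM.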

Compound 4, half-maximal inhibitory concentration: 18200 nM
Beside the measured number, compound 4's estimate is 2.0-fold (0.31 log units) below it; low and high end bracket the measured number.
By their numbers in this assay, from the lowest: compound 3; then compounds 1, 4 and 2 (each within the scatter of the next).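

In this assay, 4-chlorophenyl in place of 2-methoxyphenyl on a double-bonded chain carbon bound to a double-bonded chain carbon gives a 1.0-fold lower number from compound 2 to compound 4 (0.02 log units; within the scatter). This position therefore takes a chlorine-bearing ring as well as a methoxy-bearing one without separating the two compounds, which the methoxy-only compounds could not show. Nothing available explains this result.

The step swaps the whole group, so the parts played by losing the methoxy and gaining the chlorine stay unresolved. Also open, as far as these compounds go, is how a phenyl carrying an amine or a carboxylic acid would read here.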